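A Sulfur Linker in Place of Oxygen

This account rests on a few compounds, and the source may have more. Where it says the series, first, only, none or still open, it means among the compounds named here.

Of the compounds shown here, three that share a core have been measured in a functional assay on NCI-H460 cells (Homo sapiens) for inhibition, read by sulforhodamine B assay, with a stated time of 48 h; a higher number here means a weaker inhibitor of growth, a lower number a stronger inhibitor of growth. Compound 1 `Nc1cc(N)c2nc(-c3ccccc3)c(Oc3ccc(Cl)c(Cl)c3)nc2c1` gives 18200 nM. Compound 2 `CCOC(=O)[C@H](CCC(=O)O)NC(=O)c1ccc(CNc2nc3cc(N)cc(N)c3nc2-c2ccccc2)cc1` gives 31600 nM, and compound 3 `COc1cc(CNc2nc3cc(N)cc(N)c3nc2-c2ccccc2)cc(OC)c1OC` gives 1510 nM. Among these three numbers compound 1 stands second highest; its nearest neighbour is compound 2, within the usual scatter of this assay, while compound 3 lies far below it, beyond the scatter.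

Compound 4 `Nc1cc(N)c2nc(-c3ccccc3)c(Sc3ccc(Cl)c(Cl)c3)nc2c1` is not yet measured. It differs from compound 1 in one place: (3,4-dichlorophenyl)sulfanyl in place of 3,4-dichlorophenoxy on an aromatic carbon. The group that leaves has one oxygen and the group that enters has one sulfur; otherwise both carry the same six carbons and two chlorines on one six-membered aromatic ring of carbon only.

Going by the values given here, no measured pair shows such an exchange, so nothing in the data tells how large its effect is. The estimate is that the step of a 1.2-fold lower number from compound 1 to compound 4 (0.08 log units; within the scatter) is expected to stay within the scatter. Compound 4 is expected to give 15000 nM, with a range from 5000 nM to 45000 nM.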

Compound 4, concentration for 50% growth inhibition: 10500 nM
For compound 4 the middle estimate is 1.4-fold (0.15 log units) above the measured one; low and high end bracket the measured number.
By their numbers in this assay, from the lowest: compound 3; then compounds 4, 1 and 2 (each within the scatter of the next, the first and the last beyond it).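

In this assay, going by these compounds alone, the exchange on this aromatic carbon, next to the ring nitrogen, gives a 1.7-fold lower number from compound 1 to compound 4 (0.24 log units; within the scatter), the first direct reading of any single change at this place. Within this one pair, a sulfur can stand in for the oxygen that joins the 3,4-dichlorophenyl ring to the shared core without a step that can be told from the scatter, so the two compounds cannot be ranked against each other. The data give no measurement that could account for this step.

What the compounds shown leave open is how a sulfone or a methylene in place of this sulfur would read in this assay. They also leave open whether the same exchange would give a step of similar size with fluorine in place of the two chlorines.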